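A few compounds are considered here, and "the series" means these few. Any claim that something is new, unique, unknown or untested is made for them only; others in the source may bear on it.

Of the compounds shown here, two have been measured in an assay for inhibition of beta-galactosidase (Bos taurus), read by spectrophotometry; on this read-out lower numbers stand for stronger inhibition and higher numbers for weaker inhibition. Compound 1 `CCCCCCCCCCCC/N=C1/SC[C@@H]2[C@@H](O)[C@H](O)[C@@H](CO)N12` gives 32000 nM in this assay. Compound 2 `CCCCCC/N=C1/SC[C@H]2[C@H](O)[C@@H](O)[C@H](CO)N12` differs from compound 1 both in the length of the chain on the double-bonded nitrogen and in the configuration of the shared core. In this assay compound 2 gives 599000 nM and stands at the highest of the two numbers, well beyond the scatter from compound 1. Going by the values given here, no pair measured so far differs in one place, so the two values only show that the shorter chain and the mirrored core together go with the weaker number.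

Compound 3 `CCCCCCCCCCCC/N=C1/SC[C@H]2[C@H](O)[C@@H](O)[C@H](CO)N12` keeps the core of compound 2 and carries the change (hexyl in place of hydrogen on a saturated chain carbon, six bonds along the chain from a double-bonded nitrogen), so that it matches compound 1 in the chain and compound 2 in the core. Among the compounds with values here, the chain lengthening is the only change from compound 2, and its effect has not been separated from that of the core. A step from compound 2 to compound 3 of a 4.0-fold lower number from compound 2 to compound 3 (0.60 log units; beyond the scatter) in this assay is expected, downward and beyond the scatter. Compound 3 is therefore estimated at 150000 nM in this assay, with a range from 30000 nM to 800000 nM.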

Compound 3, half-maximal inhibitory concentration: 11000 nM
The estimate for compound 3 lay 14-fold (1.13 log units) above the measured number, and the stated range ends above it.
By their numbers in this assay, from the lowest: compound 3; then compound 1; then compound 2.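

Going by these compounds alone, with compound 3, the effect of the chain can be read apart from the core for the first time: in this assay, hexyl in place of hydrogen on a saturated chain carbon, six bonds along the chain from a double-bonded nitrogen, gives a 54-fold lower number from compound 2 to compound 3 (1.74 log units; beyond the scatter) on the core shared by these two compounds, a large step. With the chain held the same, the change of core gives only a 2.9-fold lower number from compound 1 to compound 3 (0.46 log units; beyond the scatter) as a modest step beyond the scatter, and its direction shows that the core of compound 3 goes with the lower number, so the high number of compound 2 goes with its shorter chain and not with its core. The smaller step can be assigned to configuration alone: the fact that compounds 1 and 3 differ only in the configuration as drawn.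

Whether the same hexyl change brings a step of similar size on the core of compound 1 remains open, as the compounds shown give that step on one core only. Also open, going by these compounds, is how the number would move with a still longer chain, or with a chain ending in an amine or a carboxylic acid.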